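A few compounds are considered here, and "the series" means these few. Any claim that something is new, unique, unknown or untested is made for them only; others in the source may bear on it.

Compound 1 is `COc1cccc(/C=C/C(=O)c2ccc(OC)c3c2OC(C)(C)C=C3)c1`; in a functional assay on SK-OV-3 cells (Homo sapiens) for antiproliferative activity, read by MTT assay, with a stated time of 24 h (a lower number here means a stronger inhibitor, a higher number a weaker inhibitor), compound 1 gives 9360 nM. Compound 2 is `COc1ccc(C(=O)/C=C/c2ccc(F)cc2)c2c1C=CC(C)(C)O2`; in this assay compound 2 reaches only a limit, > 10000 nM. Compound 3 is `COc1ccc(C(=O)/C=C/c2ccccc2Cl)c2c1C=CC(C)(C)O2`; in this assay compound 3 likewise stops at a limit, > 10000 nM.

Compound 2 therefore stands at the limit of > 10000 nM in this assay, at which 2 of the 3 values shown sit, with no number of its own. The move from compound 1 gave an at least 1.0-fold higher number from compound 1 to compound 2 (0.02 log units; that floor lies within the scatter), and the move to compound 3 gave a step that the two limits leave unreadable from compound 2 to compound 3, so neither step fixes a size or direction for the phenyl substituent. Compound 4 is `COc1ccc(C(=O)/C=C/c2ccc(O)c(Br)c2)c2c1C=CC(C)(C)O2`; the change is 3-bromo-4-hydroxyphenyl in place of 4-fluorophenyl on a double-bonded chain carbon bound to a double-bonded chain carbon. With both neighbouring steps unreadable, the expectation for compound 4 is a number no higher from compound 2 to compound 4 (the limit leaves the size open), i.e. no step beyond the scatter. Compound 4 is thus estimated at 10000 nM, with a range of 3000 nM to 30000 nM, and a limit is again quite possible.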

Compound 4, half-maximal inhibitory concentration: > 10000 nM
Compound 4: only a limit was reported (the forecaster's own chance of this, stated with the estimate: 55%); the middle value sits exactly at the limit.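

In this assay, among the compounds shown here, 3-bromo-4-hydroxyphenyl on the double-bonded chain carbon brings a hydrogen-bond donor that the earlier compounds lack, yet compound 4 also reaches only a limit, not a number: the limit of > 10000 nM in this assay, at which 3 of the 4 values shown sit. For the compounds shown here, the only readable new step is an at least 1.0-fold higher number from compound 1 to compound 4 (0.02 log units; that floor lies within the scatter); the other new steps cannot be read, since both ends are limits. This change therefore adds no measurable difference at this position.

Going by these compounds, it remains open how far above the limit compound 2, compound 3 and compound 4 lie. On these data alone, it is also open whether an amine or a carboxylic acid on this phenyl would give a number.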